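Removing the amide methyl: compound 3 to compound 4

The source may report more compounds than this note shows. Statements on the series, on what has been measured and on what is new or still open speak of the compounds shown alone.

Compound 3 `CNC(=O)c1ccc(-c2nc(COc3cc(OC)cc4oc(-c5cn6nc(OC)sc6n5)cc34)cs2)cc1` is the lowest of the three numbers recorded in a functional assay on HEK293 cells for antagonist activity at proteinase-activated receptor 4 (Homo sapiens), read by FLIPR and calcium flux, with a stated time of 30 min (a lower number here means a stronger inhibitor, a higher number a weaker inhibitor), where compound 3 gives 0.4 nM. Its nearest neighbour is compound 2 `COc1cc(OCc2csc(-c3cccc(C(=O)N(C)C)c3)n2)c2cc(-c3cn4nc(OC)sc4n3)oc2c1`, which in this assay gives 0.8 nM; the gap a 2.0-fold lower number from compound 2 to compound 3 (0.30 log units; within the scatter) is within the scatter, so the two cannot be ordered. Compound 1 `COc1cc(OCc2csc(-c3ccc(C(F)(F)F)cc3)n2)c2cc(-c3cn4nc(OC)sc4n3)oc2c1` gives 1.3 nM, and the step of a 3.3-fold lower number from compound 1 to compound 3 (0.51 log units; beyond the scatter) is beyond the scatter; the step of a 1.6-fold lower number from compound 1 to compound 2 (0.21 log units; within the scatter) is within it.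

Compound 4 `COc1cc(OCc2csc(-c3ccc(C(N)=O)cc3)n2)c2cc(-c3cn4nc(OC)sc4n3)oc2c1` differs from compound 3 by hydrogen in place of methyl on an amide-type nitrogen. Going by the values given here, no measured step trims an amide nitrogen in this way. The steps that touch the amide at all, a 2.0-fold lower number from compound 2 to compound 3 (0.30 log units; within the scatter) and a 3.3-fold lower number from compound 1 to compound 3 (0.51 log units; beyond the scatter), show that a carboxamide on that aryl group sits in the low range, with differences between amide variants no larger than the scatter. Compound 4 is therefore expected to stay close to compound 3, with no step beyond the scatter in this assay; the expected step is a 1.3-fold higher number from compound 3 to compound 4 (0.10 log units; within the scatter). For compound 4 the estimate in this assay is 0.5 nM, with a range from 0.2 nM to 1.3 nM.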

Compound 4, half-maximal inhibitory concentration: 0.3 nM
Compound 4: middle estimate off by 1.7-fold (0.22 log units), on the high side, and the stated range covers the measured number.
By their numbers in this assay, from the lowest: compounds 4, 3, 2 and 1 (each within the scatter of the next, the first and the last beyond it).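

In this assay, going by these compounds alone, this is the first step that changes the amide nitrogen alone, and hydrogen in place of methyl there gives a difference that cannot be ordered (a 1.3-fold lower number from compound 3 to compound 4 (0.12 log units; within the scatter)), so the methyl of the 4-(methylcarbamoyl)phenyl group is not needed for a number in this low range. The unsubstituted 4-carbamoylphenyl group also extends the earlier picture, as compound 4 stands clear of both the 3-(dimethylcarbamoyl)phenyl compound (a 2.7-fold lower number from compound 2 to compound 4 (0.43 log units; beyond the scatter)) and the 4-(trifluoromethyl)phenyl compound (a 4.3-fold lower number from compound 1 to compound 4 (0.64 log units; beyond the scatter)), although the first of these gaps should be read with care, since compound 3 and compound 4 themselves cannot be ordered and the earlier step from compound 2 to compound 3 lay within the scatter. Nothing shown here offers an explanation for these numbers.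

The compounds shown leave open whether an ethyl group, a longer chain or a ring on the amide nitrogen would stay in this range, and whether a carboxylic acid or an aminomethyl group could replace the carbamoyl group. They also leave open how the 4-(dimethylcarbamoyl)phenyl and 3-carbamoylphenyl groups would compare, which would separate the amide's place on the aryl group from its degree of methylation.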